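Swapping the urea for a carbamate on the ring nitrogen

This account rests on a few compounds, and the source may have more. Where it says the series, first, only, none or still open, it means among the compounds named here.

Of the compounds shown here, two sharing one core have been measured in a physicochemical assay for lipophilicity, at pH 7.4; on this read-out lower numbers stand for lower lipophilicity and higher numbers for higher lipophilicity. Going by the values given here, compound 1 `CCS(=O)(=O)N1C[C@H](C(=O)Nc2ccc(Cl)cc2)[C@@H](C(=O)Nc2ccc(-n3ccccc3=O)cc2F)C1` gives 2.44, and compound 2 `O=C(Nc1ccc(Cl)cc1)[C@H]1CN(C(=O)N2CCCC2)C[C@@H]1C(=O)Nc1ccc(-n2ccccc2=O)cc1F` gives 2.78, the higher of the two numbers; the only measured step, a number 0.34 log units higher from compound 1 to compound 2 (beyond the scatter), links them. Compound 3 `CCCOC(=O)N1C[C@H](C(=O)Nc2ccc(Cl)cc2)[C@@H](C(=O)Nc2ccc(-n3ccccc3=O)cc2F)C1` differs from compound 2 in one place: propoxy in place of pyrrolidin-1-yl on a carbonyl carbon. Among the compounds with values here, no measured step matches this change, so the step from compound 1 to compound 2 is the only guide, and it concerns a different group on the same ring nitrogen. Replacing the pyrrolidin-1-yl by propoxy removes one ring and adds one hydrogen-bond acceptor, a change of about the size seen before. For compound 3 an upward step of a number 0.42 log units higher from compound 2 to compound 3 (beyond the scatter) is expected in this assay. Compound 3 is therefore estimated at 3.2, within a range from 2.7 to 3.7.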

Compound 3, distribution coefficient: 3.06
Compound 3: middle estimate off by 0.14 log units, on the high side, and the stated range covers the measured number.
By their numbers in this assay, from the lowest: compound 1; then compounds 2 and 3 (each within the scatter of the next).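

On the carbonyl carbon whose other neighbour is the amide-type nitrogen in a ring, propoxy in place of pyrrolidin-1-yl gives in this assay a step of a number 0.28 log units higher from compound 2 to compound 3 (within the scatter) and so does not separate an open chain holding oxygen from a ring holding nitrogen on this read-out. Measured against the ethylsulfonyl of compound 1, propoxycarbonyl gives a number 0.62 log units higher from compound 1 to compound 3 (beyond the scatter) and (pyrrolidin-1-yl)carbonyl gives a number 0.34 log units higher from compound 1 to compound 2 (beyond the scatter) as a second step in the same direction, so a second carbonyl-linked group now lies beyond the scatter from the sulfonyl compound. Nothing measured here accounts for these numbers.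

Going by these compounds, whether a shorter chain such as ethoxy, a longer chain such as butoxy or an open amine such as dimethylamino on the same carbonyl carbon would stand beyond the scatter from propoxy remains open. On these data alone, how any of these groups would behave in a read-out other than this assay also remains open.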